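Swapping the amide-bearing ring on an acetylated core

The source may report more compounds than this note shows. Statements on the series, on what has been measured and on what is new or still open speak of the compounds shown alone.

Compound 1, `Cc1cc(C(=O)Nc2cccc(-c3ccnc4c(N)cccc34)c2)ccc1Br`, gives 9900 nM in a functional assay on A375P cells (Homo sapiens) for antiproliferative activity, read by MTT assay, with a stated time of 48 h; on this read-out lower numbers stand for stronger inhibition and higher numbers for weaker inhibition.
Compound 2, `Nc1cccc2c(-c3cccc(NC(=O)c4ccc(C(F)(F)F)cc4C(F)(F)F)c3)ccnc12`, gives only a limit in this assay: > 20000 nM.
Compound 3, `CC(=O)Nc1cccc2c(-c3cccc(NC(=O)c4ccc(Br)c(C)c4)c3)ccnc12`, likewise gives only a limit in this assay: > 20000 nM.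

Compound 3 therefore stands at the limit of > 20000 nM in this assay, at which 2 of the 3 values shown sit; its number is a boundary of the assay, not a measured potency. Among the measured compounds shown here, the one measured step reaching it, an at least 2.0-fold higher number from compound 1 to compound 3 (0.30 log units; that floor lies within the scatter), shows that putting an acetyl on the ring nitrogen already carried the value past that boundary. Compound 4, `CC(=O)Nc1cccc2c(-c3cccc(NC(=O)c4ccc(F)c(C(F)(F)F)c4)c3)ccnc12`, keeps the acetyl and alters the other end: 4-fluoro-3-(trifluoromethyl)phenyl in place of 4-bromo-3-methylphenyl on a carbonyl carbon. For the measured compounds named here, no measured step covers this exchange on an acetylated core. Compound 2, which also carries trifluoromethyl on the amide-bearing ring, sits at the limit as well. Starting from a limit, the expected step that the limit leaves unreadable from compound 3 to compound 4 cannot be resolved and is taken as none beyond the scatter. Compound 4 is expected to give about 25000 nM, between 8000 nM and 80000 nM, most probably reported once more as a limit.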

Compound 4, half-maximal inhibitory concentration: 6800 nM
The estimate for compound 4 lay 3.7-fold (0.57 log units) above the measured number; the measured number lies below the stated range.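

In this assay, 4-fluoro-3-(trifluoromethyl)phenyl in place of 4-bromo-3-methylphenyl on a carbonyl carbon gives an at least 2.9-fold lower number from compound 3 to compound 4 (0.46 log units; beyond the scatter), so the acetyl does not by itself hold a compound at the limit. The earlier compounds shown here showed the acetyl only with 4-bromo-3-methylphenyl, so they could not show that the group on this carbonyl carbon still changes the read-out on an acetylated core. The step gives only a floor, and its full size stays unknown, because compound 3 gives a limit and not a number: the limit of > 20000 nM in this assay, at which 2 of the 4 values shown sit.

The compounds shown do not separate the part played by the fluorine from that of the trifluoromethyl, and they do not show whether the same exchange changes the value on the core of compound 1. Going by these compounds, how a nitrile or a methoxy group on this phenyl ring would read out also remains open.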